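The source may report more compounds than this note shows. Statements on the series, on what has been measured and on what is new or still open speak of the compounds shown alone.

Measured compounds:
- compound 1, `Oc1ccc(-c2cc(-c3ccccn3)nc(-c3ccccc3Cl)c2)cc1` — "not determined" (no result reported) in a functional assay on DU-145 cells (Homo sapiens) for cytotoxicity, read by CCK-8 assay and cell counting, with a stated time of 2 days; on this read-out higher numbers stand for weaker inhibition and lower numbers for stronger inhibition
- compound 2, `Oc1ccc(-c2cc(-c3cccc(Cl)c3)nc(-c3ccccn3)c2)cc1` — 35200 nM
- compound 3, `Oc1cccc(-c2cc(-c3cccc(Cl)c3)nc(-c3ccccn3)c2)c1` — "not determined" (no result reported) in this assay

Of the three compounds tested in this assay, only compound 2 has a number: in this assay compound 2 gives 35200 nM. Within the data shown here, compounds 1 and 3 have no result, so compound 2 cannot be placed above or below any other compound; it simply stands alone as the one value shown, and that value points to weak inhibition.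

The next compound, compound 4, `Oc1ccc(-c2cc(-c3ccsc3)nc(-c3cccc(Cl)c3)c2)cc1`, differs from compound 2 in one place: thiophen-3-yl in place of pyridin-2-yl on an aromatic carbon. The group that leaves and the group that enters are both single aromatic rings with one hetero atom, and the rest of the shared core is unchanged.

Among the measured compounds shown here, no step between two measured compounds is available, so there is no measured change of the same kind to lean on. The expectation is therefore a step of no more than the usual scatter in either direction, so that a 1.2-fold lower number from compound 2 to compound 4 (0.07 log units; within the scatter) is estimated to be small. Compound 4 is expected to give about 30000 nM in this assay, with a range from 10000 nM to 90000 nM.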

Compound 4, half-maximal inhibitory concentration: 6220 nM
Compound 4: the middle estimate sits 4.8-fold (0.68 log units) above what was measured; the measured number lies below the stated range.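

Putting thiophen-3-yl in place of pyridin-2-yl on the aromatic carbon next to the ring nitrogen gives a 5.7-fold lower number from compound 2 to compound 4 (0.75 log units; beyond the scatter) in this assay. This first measured step shows that the read-out responds to a change at this position, so one single aromatic ring cannot be assumed to stand in for another here. Nothing shown explains why the number falls.

The step changes ring size and hetero atom together, so the compounds shown cannot say which of the two matters, or whether either matters alone. As far as these compounds go, it also remains open how a plain phenyl ring, a furan-3-yl ring or an amine at this position would compare, and whether the same change would give a similar step on another part of the shared core.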